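Chloro in Place of Methyl: Expected Permeability of Compound 3

This account rests on a few compounds, and the source may have more. Where it says the series, first, only, none or still open, it means among the compounds named here.

Of the compounds shown here, two built on one shared core have been measured in an ADME assay for permeability, using PAMPA; a lower number here means that the compound crosses the layer more slowly, a higher number that the compound crosses the layer faster. Compound 1, `CC(C)(C)[C@H]1C(O)=C(C2=CS(=O)(=O)c3cc(NS(C)(=O)=O)ccc3N2)C(=O)N1Cc1ccc(F)cc1`, gives 1.4 10^-6 cm/s. Compound 2, `Cc1cc(CN2C(=O)C(C3=CS(=O)(=O)c4cc(NS(C)(=O)=O)ccc4N3)=C(O)[C@@H]2C(C)(C)C)ccc1F`, gives 1.62 10^-6 cm/s. Within the data shown here, the single step joining them, a 1.2-fold higher number from compound 1 to compound 2 (0.06 log units; within the scatter), lies within the scatter, so the two numbers cannot be told apart. Compound 2 holds the higher of the two numbers shown, but only by a margin that repeated runs could erase.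

Compound 3, `CC(C)(C)[C@H]1C(O)=C(C2=CS(=O)(=O)c3cc(NS(C)(=O)=O)ccc3N2)C(=O)N1Cc1ccc(F)c(Cl)c1`, differs from compound 2 in one place: chloro in place of methyl on an aromatic carbon. Among the measured compounds shown here, no measured step exchanges chloro for methyl, so the only guide is the step that put methyl in place of hydrogen, a 1.2-fold higher number from compound 1 to compound 2 (0.06 log units; within the scatter), which stayed within the scatter. Both groups entering and leaving are single heavy atoms, and the count of hydrogen-bond donors and acceptors does not move, so the step of a 1.0-fold higher number from compound 2 to compound 3 (0.02 log units; within the scatter) is expected to stay within the scatter as well. Compound 3 is therefore estimated at 1.7 10^-6 cm/s, with a range from 1 10^-6 cm/s to 2.9 10^-6 cm/s.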

Compound 3, apparent permeability: 0.98 10^-6 cm/s
The estimate for compound 3 lay 1.7-fold (0.24 log units) above the measured number; the measured number lies below the stated range.
By their numbers in this assay, from the lowest: compounds 3, 1 and 2 (each within the scatter of the next).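

At this position of the benzyl group, a single aromatic carbon has now carried hydrogen, methyl and chloro, and in this assay the exchange of methyl for chloro gives a 1.7-fold lower number from compound 2 to compound 3 (0.22 log units; within the scatter) while the exchange of hydrogen for chloro gives a 1.4-fold lower number from compound 1 to compound 3 (0.15 log units; within the scatter) as its reading. Together with the earlier methyl step, this means that all three pairs at this position stay within the scatter, so the three compounds cannot be put in a firm order, even though the chloro compound has the smallest printed number. Chloro and methyl each add one heavy atom with no hydrogen-bond donors or acceptors and no net charge, yet no reason for the small differences seen here can be offered, as nothing further is available on what underlies them.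

From the compounds shown here alone, how an amine, a carboxylic acid or a longer chain such as propyl would read at this same carbon stays open, as these groups differ from hydrogen, methyl and chloro in ways the three compounds do not sample. Going by these compounds, all three compounds also keep the fluoro group, so whether chloro or methyl would read the same without it remains unknown.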